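Swapping a benzyl for 4-chlorophenoxy on a shared core

This account rests on a few compounds, and the source may have more. Where it says the series, first, only, none or still open, it means among the compounds named here.

Measured so far:
- compound 1, `COc1ccc(F)cc1CNCCCNc1ccnc2cc(C3CCCCC3)ccc12`: 4200 nM
- compound 2, `c1ccc(Cc2ccc3c(NCCCNCc4ccco4)ccnc3c2)cc1`: 4200 nM
- compound 3, `COc1ccc(F)cc1CNCCCNc1ccnc2cc(Cc3ccccc3)ccc12`: 4200 nM

In a physicochemical assay for solubility, with a stated time of 18 h, at pH 7.4 (a higher number here means a more soluble compound, a lower number a less soluble compound), compound 3 gives 4200 nM and stands level with compound 1 and compound 2. The two changes that lead to compound 3 left the read-out alone: no change at the digits printed from compound 1 to compound 3 (within the scatter) and no change at the digits printed from compound 2 to compound 3 (within the scatter) are both within the scatter.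

Compound 4 is `COc1ccc(F)cc1CNCCCNc1ccnc2cc(Oc3ccc(Cl)cc3)ccc12`. It differs from compound 3 at one spot: 4-chlorophenoxy in place of benzyl on an aromatic carbon. The step from compound 1 to compound 3 is the only one that touches the same aromatic carbon, and it shows no change, so the read-out has so far been insensitive to what sits at that place. Within the data shown here, no measured step brings in a 4-chlorophenoxy group, so the expectation rests on that insensitivity alone.

For compound 4 the step of no change at the digits printed from compound 3 to compound 4 (within the scatter) is expected, which is to say no change beyond the scatter. Compound 4 is estimated to give 4200 nM in this assay, within a range from 2000 nM to 8000 nM.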

Compound 4, solubility: 14500 nM
The estimate for compound 4 lay 3.5-fold (0.54 log units) below the measured number; the whole stated range lies below it.
By their numbers in this assay, from the lowest: compounds 1, 2 and 3 (each within the scatter of the next); then compound 4.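

In this assay, this aromatic carbon turns out not to be indifferent to what it carries: 4-chlorophenoxy in place of benzyl gives a 3.5-fold higher number from compound 3 to compound 4 (0.54 log units; beyond the scatter), and 4-chlorophenoxy in place of cyclohexyl gives a 3.5-fold higher number from compound 1 to compound 4 (0.54 log units; beyond the scatter). Benzyl and cyclohexyl could be exchanged here without a change beyond the scatter, so the flat read-out among the earlier compounds described only those two groups and not the position as a whole. Nothing shown here explains why the number rises, since no supporting measurement bears on this result.

The step brings in an oxygen and a chlorine at once, and the enters-and-leaves count separates neither: a plain phenoxy group or a 4-chlorobenzyl group at this carbon would be needed to tell which of the two goes with the higher number. As far as these compounds go, it also remains open whether 4-chlorophenoxy has the same effect on the read-out when furan-2-yl takes the place of 5-fluoro-2-methoxyphenyl on the chain.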